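The source may report more compounds than this note shows. Statements on the series, on what has been measured and on what is new or still open speak of the compounds shown alone.

Going by the values given here, compound 3 `O=C(Nc1ccccc1O)C1CCc2ccccc2N1C(=O)c1ccccc1` gives 3490 nM in a functional assay on NCI-H23 cells (Homo sapiens) for cytotoxicity, read by sulforhodamine B assay, with a stated time of 72 h (a lower number here means a stronger inhibitor of growth, a higher number a weaker inhibitor of growth), and has the lowest number of the three compounds measured so far. Compound 1 `CC(=O)N1c2ccccc2CCC1C(=O)Nc1ccccc1O` gives 65700 nM in this assay, and compound 2 `CCCCCCCCC(=O)N1c2ccccc2CCC1C(=O)Nc1ccccc1O` gives 55800 nM there. The step of a 19-fold lower number from compound 1 to compound 3 (1.27 log units; beyond the scatter) and the step of a 16-fold lower number from compound 2 to compound 3 (1.20 log units; beyond the scatter) are both large and beyond the scatter, so compound 3 is the most potent of the measured set; the step of a 1.2-fold lower number from compound 1 to compound 2 (0.07 log units; within the scatter) is within the scatter.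

Compound 4 `O=C(Nc1ccccc1O)C1CCc2ccccc2N1C(=O)c1cccc(Cl)c1` differs from compound 3 by chloro in place of hydrogen on an aromatic carbon. Among the compounds with values here, all three measured steps change the group on the carbonyl carbon attached to the ring nitrogen; none of them alters an aromatic ring in the way compound 4 does, so no measured step speaks directly to this change. In the absence of such a precedent, he expects no step beyond the scatter, and estimates that the step from compound 3 to compound 4 will be a 1.2-fold lower number from compound 3 to compound 4 (0.07 log units; within the scatter). Compound 4 is therefore expected to give about 3000 nM in this assay, within a range from 1000 nM to 9000 nM.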

Compound 4, concentration for 50% growth inhibition: 11600 nM
The estimate for compound 4 lay 3.9-fold (0.59 log units) below the measured number; measured number above the stated range.
By their numbers in this assay, from the lowest: compound 3; then compound 4; then compounds 2 and 1 (each within the scatter of the next).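

Chloro in place of hydrogen on the six-membered aromatic ring, meta to a large group, shows that this ring is not indifferent to substitution in this assay: the change gives a 3.3-fold higher number from compound 3 to compound 4 (0.52 log units; beyond the scatter). The advantage of an aromatic group on the carbonyl carbon survives in part, with 3-chlorophenyl in place of octyl giving a 4.8-fold lower number from compound 2 to compound 4 (0.68 log units; beyond the scatter) and 3-chlorophenyl in place of methyl giving a 5.7-fold lower number from compound 1 to compound 4 (0.75 log units; beyond the scatter), both smaller than the corresponding steps with phenyl. Nothing measured here accounts for the effect of the chloro group.

The compounds shown leave open how a methoxy group, an amine or a carboxylic acid would read at this same place, and whether chloro would read differently elsewhere on the ring. From the compounds shown here alone, the hydroxyl group on the anilide ring stays the same throughout, so its contribution also remains open.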